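Swapping the ring-bearing chain on compound 3

The compounds below may be only part of what the source reports. "The series", "measured", "known", "first", "only" and "open" are said of these compounds alone.

Of the compounds shown here, three sharing one core have been measured in an assay for binding affinity to Corticotropin releasing factor receptor (Rattus norvegicus); a lower number here means a stronger inhibitor, a higher number a weaker inhibitor. Compound 1 `CCc1nc2c(-c3ccc(OC)nc3C)ccnc2n1C(CC)C1CC1` gives 0.7 nM, compound 2 `CCCC(C)n1c(CC)nc2c(-c3ccc(OC)nc3C)ccnc21` gives 1.1 nM, and compound 3 `CCc1nc2c(-c3ccc(Cl)nc3C)ccnc2n1C(CC)C1CC1` gives 3.3 nM. Compound 3 thus stands highest of the three numbers: compound 2 lies nearest to it, with a number lower than that of compound 3 by a distance beyond the scatter, and compound 1 lies furthest, lower still. The step of a 4.7-fold higher number from compound 1 to compound 3 (0.67 log units; beyond the scatter) accounts for that distance, with chloro in place of methoxy on an aromatic carbon.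

Compound 4 `CCCC(C)n1c(CC)nc2c(-c3ccc(Cl)nc3C)ccnc21` carries the same chloro as compound 3 and differs from it in one place: 1-methylbutyl in place of 1-cyclopropylpropyl on an aromatic nitrogen. Among the compounds with values here, the one measured step that bears on this change is a 1.6-fold higher number from compound 1 to compound 2 (0.20 log units; within the scatter), where the same exchange of chains occurred against the methoxy-bearing core and stayed within the scatter. The expectation for compound 4 is therefore a step of a 1.5-fold higher number from compound 3 to compound 4 (0.18 log units; within the scatter) that again stays within the scatter, if anything slightly upward. Compound 4 is estimated at 5 nM, with a range from 2 nM to 12 nM.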

Compound 4, inhibition constant: 6.6 nM
Compound 4: the middle estimate sits 1.3-fold (0.12 log units) below what was measured, and the stated range covers the measured number.
By their numbers in this assay, from the lowest: compounds 1 and 2 (each within the scatter of the next); then compounds 3 and 4 (each within the scatter of the next).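

In this assay, the exchange of chains on the aromatic nitrogen has now been read with the chloro in place as well as with the methoxy, and the step of a 2.0-fold higher number from compound 3 to compound 4 (0.30 log units; within the scatter) shows that 1-cyclopropylpropyl and 1-methylbutyl are not told apart on either core: the same change on two cores in this assay, a 1.6-fold higher number (0.20 log units; within the scatter) from compound 1 to compound 2 and a 2.0-fold higher number (0.30 log units; within the scatter) from compound 3 to compound 4, 1.3-fold (0.10 log units) apart, within the scatter of two such steps The exchange of chloro for methoxy on the aromatic carbon, until now read only with 1-cyclopropylpropyl, also holds with 1-methylbutyl, where the step of a 6.0-fold higher number from compound 2 to compound 4 (0.78 log units; beyond the scatter) again lies beyond the scatter: the same change on two cores in this assay, a 4.7-fold higher number (0.67 log units; beyond the scatter) from compound 1 to compound 3 and a 6.0-fold higher number (0.78 log units; beyond the scatter) from compound 2 to compound 4, 1.3-fold (0.10 log units) apart, within the scatter of two such steps Across these four compounds, then, the number follows the group on the aromatic carbon, and the two exchanges behave much the same whichever partner is present.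

Going by these compounds, both chains compared here are branched and purely carbon, so it remains open whether a longer chain, a benzyl group or a chain carrying a methoxy group would also stay within the scatter on the aromatic nitrogen. On these data alone, it is also open whether a nitrile, a fluoro or a dimethylamino group on the aromatic carbon would fall nearer to the methoxy or to the chloro.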